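Nitro Added Where Both Measured Compounds Reach Only a Limit

The source may hold more compounds than are shown below. What is called first, only, known or untested is meant among the compounds shown, and "the series" means these compounds.

Compound 1 `Cc1cccc(NC2=C(Nc3cccc(C)c3)C(=O)c3ccccc3C2=O)c1` stands at a limit rather than at a number in an ADME assay on L6 cells (Rattus norvegicus) for cytotoxicity, read by sulforhodamine B assay, with a stated time of 72 h; on this read-out lower numbers stand for stronger inhibition and higher numbers for weaker inhibition. In this assay compound 1 gives > 450000 nM, which is a limit of the assay. Compound 2 `Cc1ccccc1NC1=C(Nc2ccccc2C)C(=O)c2ccccc2C1=O` is in the same position: in this assay compound 2 gives > 450000 nM, again a limit. The only figure shown across the measured set is the limit of > 450000 nM in this assay, at which 2 of the 2 values shown sit, so the numbers do not place compound 1 above or below compound 2.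

Compound 3 `Cc1cccc(NC2=C(Nc3cccc(C)c3)C(=O)c3c(cccc3[N+](=O)[O-])C2=O)c1` has not yet been measured in this assay. It differs from compound 1 by nitro in place of hydrogen on an aromatic carbon. For the measured compounds named here, no measured pair shares this change, so no measured step guides the outlook. The step of an at least 1.1-fold lower number from compound 1 to compound 3 (0.05 log units; that floor lies within the scatter) is expected to be small, most likely leaving compound 3 at the limit as well. Compound 3 is therefore estimated at 400000 nM, with a range from 100000 nM to 450000 nM.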

Compound 3, half-maximal inhibitory concentration: 195000 nM
Estimate against measurement, compound 3: 2.1-fold (0.31 log units) above; measured number inside the range.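

For the compounds shown here, compound 3 is the first compound here to give a number rather than a limit in this assay, and nitro in place of hydrogen on an aromatic carbon produces an at least 2.3-fold lower number from compound 1 to compound 3 (0.36 log units; beyond the scatter). Going by these compounds alone, this shows that the read-out responds to a change at this place on the fused system of two rings, something the earlier compounds could not show. The full size of the step cannot be read, since compound 1 stands at a limit and not at a number: the limit of > 450000 nM in this assay, at which 2 of the 3 values shown sit.

The compounds shown leave open whether an amine or a carboxylic acid at this same place would also lower the number, or whether the step is particular to nitro. They also leave open whether nitro would bring a number on the core of compound 2.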